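Fluorines on the Distal Aryl of a Pyridine-Carboxamide Series

The source may report more compounds than this note shows. Statements on the series, on what has been measured and on what is new or still open speak of the compounds shown alone.

Measured compounds:
Compound 1 `Cc1ccc(-c2ccnc(C(=O)Nc3ccc(Oc4ccnc5[nH]ccc45)cc3)c2)cc1` — > 10000 nM
Compound 2 `Cc1ccc(-c2ccnc(C(=O)Nc3ccc(Oc4ccnc5[nH]ccc45)c(F)c3)c2)cc1` — 3970 nM

Compound 1 reaches only a limit in a functional assay on PC-3 cells (Homo sapiens) for cytotoxicity, read by MTT assay, with a stated time of 72 h; a higher number here means a weaker inhibitor, a lower number a stronger inhibitor (the limit of > 10000 nM in this assay, at which 1 of the 2 values shown sits). Among the measured compounds shown here, compound 2 gives the only actual number in this assay, 3970 nM. The step is an at least 2.5-fold lower number from compound 1 to compound 2 (0.40 log units; beyond the scatter).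

Compound 3 `O=C(Nc1ccc(Oc2ccnc3[nH]ccc23)c(F)c1)c1cc(-c2ccc(F)cc2F)ccn1` differs from compound 2 in this way: 2,4-difluorophenyl in place of 4-methylphenyl on an aromatic carbon. For the measured compounds named here, the one measured step concerns a fluoro entering elsewhere on the shared core, not the 4-methylphenyl group, so it offers no direct guide to this change. Going by the values given here, with no step at the changed position to lean on, the expectation is a step from compound 2 to compound 3 of a 1.3-fold lower number from compound 2 to compound 3 (0.12 log units; within the scatter), within the scatter or at most modest. Compound 3 is therefore estimated at 3000 nM, with a range from 900 nM to 12000 nM.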

Compound 3, half-maximal inhibitory concentration: > 10000 nM
Compound 3 ended at the assay's limit (the forecaster's own chance of this, stated with the estimate: 20%); at least 3.3-fold (0.52 log units) between middle value and limit.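

At the aromatic carbon opposite the ring nitrogen, 2,4-difluorophenyl in place of 4-methylphenyl moves this assay in the opposite direction to the earlier fluoro on the shared core, with an at least 2.5-fold higher number from compound 2 to compound 3 (0.40 log units; beyond the scatter) as the step. Among the compounds shown here, the earlier compounds showed only that the shared core responds to a change; this result shows that the group at this position matters as well, and that fluorines here do not repeat the gain seen with the core fluoro. The size of the step is known from one side only, as compound 3 reaches a limit of the assay: the limit of > 10000 nM in this assay, at which 2 of the 3 values shown sit.

On these data alone, how 4-aminophenyl, 4-methoxyphenyl or unsubstituted phenyl would read at this position remains open. So does whether a single fluoro on the phenyl ring would be tolerated, and how a carboxylic acid there would behave.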